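Swapping the Chloroethenyl Warhead for a Pentenyl Chain

The compounds below may be only part of what the source reports. "The series", "measured", "known", "first", "only" and "open" are said of these compounds alone.

Compound 3 `C=C(Cl)C(=O)Nc1cc(Nc2ncc(C#N)c(-c3cn(C)c4ccccc34)n2)c(OC)cc1N(C)CCN(C)C` has the lowest of the two numbers given in a functional assay on A549 cells (Homo sapiens) for antiproliferative activity, read by MTT assay, with a stated time of 72 h; a higher number here means a weaker inhibitor, a lower number a stronger inhibitor: compound 3 gives 133 nM. Compound 1 `C=C(Cl)C(=O)Nc1cc(Nc2nccc(-c3cn(C)c4ccccc34)n2)c(OC)cc1N(C)CCN(C)C` gives 7520 nM in this assay, and the gap is the step of a 57-fold lower number from compound 1 to compound 3 (1.75 log units; beyond the scatter), which comes from the nitrile alone. Compound 2 `COc1cc(N(C)CCN(C)C)c(NC(=O)C(Cl)=C(Cl)Cl)cc1Nc1nccc(-c2cn(C)c3ccccc23)n1` returns only a limit of the assay, > 50000 nM, and the limit of > 50000 nM in this assay, at which 1 of the 3 values shown sits, records it. The step of an at least 6.6-fold higher number from compound 1 to compound 2 (0.82 log units; beyond the scatter) therefore shows that enlarging the group on the carbonyl carbon cost potency beyond the scatter.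

Compound 4 `CCC/C=C\C(=O)Nc1cc(Nc2ncc(C#N)c(-c3cn(C)c4ccccc34)n2)c(OC)cc1N(C)CCN(C)C` differs from compound 3 in the same position: pent-1-en-1-yl in place of 1-chloroethenyl on a carbonyl carbon. Within the data shown here, the nitrile that made compound 3 strong stays in place, so the only measured step that bears on this change is the one from compound 1 to compound 2, in which the carbonyl-bound group was altered and the number rose, at least modestly. A loss of similar or somewhat smaller size is expected here, though the new chain is not the same group. Compound 4 is therefore expected to give 800 nM, with a range from 150 nM to 5000 nM. The expected step is a 6.0-fold higher number from compound 3 to compound 4 (0.78 log units; beyond the scatter).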

Compound 4, half-maximal inhibitory concentration: 166 nM
The estimate for compound 4 lay 4.8-fold (0.68 log units) above the measured number; the measured number falls inside the stated range.
By their numbers in this assay, from the lowest: compounds 3 and 4 (each within the scatter of the next); then compound 1. At a limit, above all of these: compound 2.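

In this assay, pent-1-en-1-yl in place of 1-chloroethenyl on a carbonyl carbon gives a 1.2-fold higher number from compound 3 to compound 4 (0.10 log units; within the scatter), so on the nitrile-bearing core this position accepts a chain without chlorine and with more heavy atoms. Among these compounds, the only earlier step at this position, an at least 6.6-fold higher number from compound 1 to compound 2 (0.82 log units; beyond the scatter), showed a loss, so changing the group here does not always cost potency, although that step used a different group on a core without the nitrile. Compound 2 stands at a limit of the assay, not at a number: the limit of > 50000 nM in this assay, at which 1 of the 4 values shown sits.

Nothing shown explains why the pentenyl chain is accepted here. Still open, going by these compounds, is whether a saturated pentyl chain, a longer chain or a chain ending in an amine would hold this level, and what 1,2,2-trichloroethenyl would do on the nitrile-bearing core.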